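The compounds below may be only part of what the source reports. "The series", "measured", "known", "first", "only" and "open" are said of these compounds alone.

Compound 1, `COc1nc(N)nc2c1c(-c1ccsc1)cn2[C@@H]1O[C@H](CO)[C@@H](O)[C@H]1O`: in a functional assay on HepG2 cells (Homo sapiens) for antiproliferative activity, read by XTT assay, with a stated time of 72 h (a lower number here means a stronger inhibitor, a higher number a weaker inhibitor), compound 1 gives > 20000 nM, which is a limit of the assay rather than a number.
Compound 2, `COc1nc(N)nc2c1c(-c1cccs1)cn2[C@@H]1O[C@H](CO)[C@@H](O)[C@H]1O`: in this assay compound 2 gives > 20000 nM, again a limit.
Compound 3, `CNc1ncnc2c1c(-c1cccs1)cn2[C@@H]1O[C@H](CO)[C@@H](O)[C@H]1O`: in this assay compound 3 gives > 20000 nM, also a limit.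

Compounds 1 and 2 share a core and differ only by thiophen-3-yl in place of thiophen-2-yl on an aromatic carbon. The step from compound 2 to compound 1, a step that the two limits leave unreadable from compound 2 to compound 1, has no readable size because the limit of > 20000 nM in this assay, at which 3 of the 3 values shown sit, is where both values sit. The core of compound 3 is a different one from that of compound 2; how the two cores differ is not broken down here.

Compound 4, `CNc1ncnc2c1c(-c1ccsc1)cn2[C@@H]1O[C@H](CO)[C@@H](O)[C@H]1O`, has not yet been measured in this assay. It differs from compound 3 by thiophen-3-yl in place of thiophen-2-yl on an aromatic carbon, the same change as that from compound 2 to compound 1, made at a place described in the same words. On the core of compound 2 that change left compound 1 at the limit; compound 3 itself stands at a limit. The step from compound 3 to compound 4 is therefore expected to be a step that the limit leaves unreadable from compound 3 to compound 4. Compound 4 is estimated at 40000 nM, most likely reported again only as a limit.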

Compound 4, half-maximal inhibitory concentration: > 20000 nM
Compound 4 ended at the assay's limit; the forecaster's own chance of this, stated with the estimate: 85%; the middle value does not contradict the limit.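

No size can be read for the change from compound 3 to compound 4, since both compounds sit at the same limit rather than at a number: the limit of > 20000 nM in this assay, at which 4 of the 4 values shown sit.

The compounds shown leave open how far any of them falls beyond that limit in this assay, and whether thiophen-3-yl and thiophen-2-yl differ there on either core.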